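The source may report more compounds than this note shows. Statements on the series, on what has been measured and on what is new or still open speak of the compounds shown alone.

Measured in a functional assay on PC-3 cells (Homo sapiens) for inhibition, read by MTT assay, with a stated time of 96 h; on this read-out lower numbers stand for stronger inhibition of growth and higher numbers for weaker inhibition of growth:

Compound 1 `O=C(NCCCCCCSSCCCCCCNC(=O)c1cc(-c2ccncc2)n[nH]1)c1cc(-c2ccncc2)n[nH]1` gives 4740 nM.
Compound 2 `CC(=O)SCCCCCCNC(=O)c1cc(-c2ccncc2)n[nH]1` gives 36000 nM.
Compound 3 `CCCCCCCC/C=C\CCCCCCCC(=O)SCCCCCCNC(=O)c1cc(-c2ccncc2)n[nH]1` returns a limit of the assay rather than a number: > 50000 nM.

Of the two actual numbers, compound 2 holds the higher one, meaning weaker growth inhibition; compound 1 gives a lower number, and that gap lies beyond the usual scatter. Compound 3 sits at the limit of > 50000 nM in this assay, at which 1 of the 3 values shown sits.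

Compound 4 `CC(C)C(=O)SCCCCCCNC(=O)c1cc(-c2ccncc2)n[nH]1` differs from compound 2 in one place: isopropyl in place of methyl on a carbonyl carbon. For the measured compounds named here, no measured pair shows this same change, so there is no direct guide to its effect. The expected step is a 1.1-fold higher number from compound 2 to compound 4 (0.05 log units; within the scatter), a change no larger than the scatter. Compound 4 is estimated at 40000 nM, with a likely range from 15000 nM to 100000 nM.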

Compound 4, concentration for 50% growth inhibition: 22400 nM
The estimate for compound 4 lay 1.8-fold (0.25 log units) above the measured number; low and high end bracket the measured number.
By their numbers in this assay, from the lowest: compound 1; then compounds 4 and 2 (each within the scatter of the next). At a limit, above all of these: compound 3.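

In this assay, for the compounds shown here, the isopropyl group in place of methyl on a carbonyl carbon gives a 1.6-fold lower number from compound 2 to compound 4 (0.21 log units; within the scatter) and so offers the first numerical comparison at this position. The added branching leaves growth inhibition indistinguishable from that of the methyl compound. Compound 3, changed at the same position, returns only a limit of the assay rather than a number: the limit of > 50000 nM in this assay, at which 1 of the 4 values shown sits.

On these data alone, whether a hexanoyl chain, of a length between these groups, would keep growth inhibition at this level remains open. So does the effect of placing an amine or a carboxylic acid on this carbonyl carbon.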